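The compounds below may be only part of what the source reports. "The series", "measured", "known", "first", "only" and "open" are said of these compounds alone.

Working notes on the series. Two compounds carry numbers in an assay for inhibition of inositol hexakisphosphate kinase 2 (Homo sapiens), read by colorimetric assay, coupled enzyme assay and malachite green, with a stated time of 120 min, in the presence of a further agent that is not named here; a lower number here means a stronger inhibitor, a higher number a weaker inhibitor. Compound 1, `O=C(O)/C=C/c1ccc2noc(-c3ccc(OC(F)(F)F)cc3)c2c1`, gives 320 nM in this assay. Going by the values given here, compound 2, `O=C(O)c1ccc2noc(-c3ccc(-c4ccncc4)cc3)c2c1`, gives 150 nM in this assay, the lowest of the two numbers so far; compound 1 sits at a higher number, and that gap lies beyond the scatter. Compounds 1 and 2 differ in more than one place, so their two values stand side by side without a counted step between them.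

Compound 3, `O=C(O)c1ccc2noc(-c3ccc(Cc4ccccc4)cc3)c2c1`, is still to be measured in this assay. It differs from compound 2 in one place: benzyl in place of pyridin-4-yl on an aromatic carbon. Among the compounds with values here, no measured pair tells what such a change does here. The expectation for compound 3 is a step from compound 2 of a 1.7-fold higher number from compound 2 to compound 3 (0.22 log units; within the scatter), no larger than the scatter. Compound 3 is thus estimated at 250 nM in this assay, within a range of 100 nM to 800 nM.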

Compound 3, half-maximal inhibitory concentration: 65 nM
Beside the measured number, compound 3's estimate is 3.8-fold (0.59 log units) above it; the whole stated range lies above it.
By their numbers in this assay, from the lowest: compound 3; then compound 2; then compound 1.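

At this position, on an aromatic carbon of the six-membered carbon-only ring and para to a large group, replacing pyridin-4-yl with benzyl gives a 2.3-fold lower number from compound 2 to compound 3 (0.36 log units; beyond the scatter) in this assay. A group with no hydrogen-bond acceptor and no ring nitrogen is therefore accepted here, and the number improves beyond the scatter. No measurement at hand bears on why the number falls.

This single change swaps the ring nitrogen for carbon and also adds a carbon link between the two rings, so the compounds shown do not separate these two differences. A directly attached phenyl and a pyridin-4-ylmethyl group at this position would separate them, and a longer chain such as 2-phenylethyl would show how far the link can extend.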